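A few compounds are considered here, and "the series" means these few. Any claim that something is new, unique, unknown or untested is made for them only; others in the source may bear on it.

In a functional assay on OVCAR-3 cells (Homo sapiens) for inhibition, read by sulforhodamine B assay, with a stated time of 48 h (a higher number here means a weaker inhibitor of growth, a lower number a stronger inhibitor of growth), compound 1 `CCOC(=O)c1nn(-c2ccccc2)c(-c2ccc(Br)cc2)c1CNC(C)(C)C` gives 2910 nM; > 509000 nM (2 entries). Compound 2 `CC(C)(C)NCc1c(C(=O)O)nn(-c2ccccc2)c1-c1ccc(Br)cc1` gives > 585000 nM, which is a limit and not a number. Compound 3 `CC(C)(C)NCc1c(C(=O)O)nn(-c2ccccc2)c1-c1ccccc1` gives > 716000 nM, which is also a limit. Compound 2 therefore has no exact place on the scale. Compound 4 `CC(C)(C)NCc1c(C(=O)O)nn(-c2ccc(Cl)cc2)c1-c1ccc(Br)cc1` differs from compound 2 by chloro in place of hydrogen on an aromatic carbon, with chloro in place of hydrogen on an aromatic carbon, para to a large group. Within the data shown here, the only measured step bearing on this, a step that the two limits leave unreadable from compound 2 to compound 3, swaps bromo for hydrogen and has no readable size, so no step beyond the scatter is expected in this assay. The expected change is an at least 1.0-fold lower number from compound 2 to compound 4 (0.03 log units; that floor lies within the scatter). Compound 4 is estimated at 540000 nM, within a range of 150000 nM to 800000 nM.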

Compound 4, concentration for 50% growth inhibition: 513000 nM
For compound 4 the middle estimate is 1.1-fold (0.02 log units) above the measured one, and the stated range covers the measured number.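

In this assay compound 4 gives 513000 nM, the only exact number among the carboxylic acids shown. Going from phenyl to 4-chlorophenyl, at this place para to a large group, gives an at least 1.1-fold lower number from compound 2 to compound 4 (0.05 log units; that floor lies within the scatter). For compound 2, > 585000 nM is a limit, so this step is only a floor and shows no change beyond the scatter. From the compounds shown here alone, what a methoxy group or an amine would do at this place stays open. So does whether chloro would act the same way on the ester of compound 1.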